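The source may hold more compounds than are shown below. What is called first, only, known or untested is meant among the compounds shown, and "the series" means these compounds.

Within the data shown here, in a toxicity assay on NIH3T3 cells (Mus musculus) for cytotoxicity, read by resazurin assay (on this read-out higher numbers stand for an effect only at larger amounts of compound and lower numbers for an effect already at smaller amounts), compound 2 (`COC(=O)c1ccc(NCc2cncn2Cc2ccccc2N)cc1-c1ccccc1`) gives 25000 nM, the only true number among the three values so far. Compound 1 (`COC(=O)c1ccc(NCc2cncn2Cc2ccccc2)cc1-c1ccccc1`) gives only a limit, > 1000 nM, not a number. Compound 3 (`Fc1ccc(Cn2cncc2CNc2ccc(-c3nc4ccccc4s3)c(-c3ccccc3)c2)c(F)c1`) likewise gives only a limit, > 1000 nM, not a number. Compound 4 (`COC(=O)c1ccc(NCc2cncn2Cc2cccc(N)c2)cc1-c1ccccc1`) is related to compound 2 by 3-aminophenyl in place of 2-aminophenyl on a saturated chain carbon bound to an aromatic nitrogen, with 3-aminophenyl in place of 2-aminophenyl on a saturated chain carbon bound to an aromatic nitrogen. Among the measured compounds shown here, the one measured step that bears on this is a step that the limit leaves unreadable from compound 1 to compound 2, which offers no size to carry over. No step beyond the usual scatter is therefore expected in this assay, and the estimated move is a 1.3-fold lower number from compound 2 to compound 4 (0.10 log units; within the scatter). For compound 4 the expected value is 20000 nM, with an estimated range from 6000 nM to 60000 nM.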

Compound 4, half-maximal effective concentration: > 10000 nM
Compound 4: a limit, no number; the forecaster's own chance of this, stated with the estimate: 40%; the middle value lies beyond the limit too.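

Neither the step from compound 2 to compound 4 nor the step from compound 1 to compound 4 can be read in this assay: compound 4 gives only a limit. The compounds shown leave open whether 3-aminophenyl in place of 2-aminophenyl changes the number at all.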